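Moving the Bromine Within the Methoxyphenyl Group

The source may report more compounds than this note shows. Statements on the series, on what has been measured and on what is new or still open speak of the compounds shown alone.

Compound 1, `COc1ccc(F)cc1Nc1cc(NC(=O)Nc2c(Cl)cccc2Cl)ncn1`: 85.5%
Compound 2, `Cc1ccc(Nc2cc(NC(=O)Nc3c(Cl)cccc3Cl)ncn2)cc1C`: 92.1%
Compound 3, `COc1cc(Br)ccc1Nc1cc(NC(=O)Nc2c(Cl)cccc2Cl)ncn1`: 90.5%

Three compounds with a shared core have been run in a functional assay on PC-9 cells (Homo sapiens) for inhibition, read by MTT assay, with a stated time of 48 h, tested at 10 uM (a higher number here means more inhibition at the concentration tested (going by the name of the read-out), a lower number less inhibition), so far. Compound 3 stands second highest of the three numbers. Its nearest neighbour is compound 2, and the step of a number 1.6 percentage points lower from compound 2 to compound 3 (within the scatter) lies within the scatter; its furthest is compound 1, and the step of a number 5 percentage points higher from compound 1 to compound 3 (within the scatter) also lies within the scatter. On the numbers shown, none of the three compounds can be separated from the others.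

Compound 4, `COc1ccc(Br)cc1Nc1cc(NC(=O)Nc2c(Cl)cccc2Cl)ncn1`, is the next compound to be measured. It differs from compound 3 in one place: 5-bromo-2-methoxyphenyl in place of 4-bromo-2-methoxyphenyl on a nitrogen on an aromatic ring.

Every measured step changes the aryl group on the same nitrogen: a number 6.6 percentage points higher from compound 1 to compound 2 (within the scatter), a number 5 percentage points higher from compound 1 to compound 3 (within the scatter) and a number 1.6 percentage points lower from compound 2 to compound 3 (within the scatter). All three are within the scatter, even where methoxy and halogen substituents were exchanged for dimethyl. None of them moves a bromine within an otherwise unchanged methoxyphenyl group, so the present change is not directly covered, but the measured steps give no reason to expect a step beyond the scatter for compound 4, and the step of a number 1.5 percentage points lower from compound 3 to compound 4 (within the scatter) is expected to be small. In this assay compound 4 is therefore estimated at 89%, with a range from 78% to 97%.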

Compound 4, a percentage reported as inhibition, at one concentration (the size of the read-out at that concentration, not a potency): 69%
For compound 4 the middle estimate is 20 percentage points above the measured one; the measured number lies below the stated range.
By their numbers in this assay, from the lowest: compound 4; then compounds 1, 3 and 2 (each within the scatter of the next).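

In this assay, among these compounds, moving the bromine alone, with the same atoms joined differently, gives a number 21.5 percentage points lower from compound 3 to compound 4 (beyond the scatter), the first step to go beyond the scatter and the first sign that the place of the bromine on the methoxyphenyl group on this nitrogen matters. The 5-bromo-2-methoxyphenyl group also stands apart from the other aryl groups: bromo in place of fluoro gives a number 16.5 percentage points lower from compound 1 to compound 4 (beyond the scatter), and the exchange for 3,4-dimethylphenyl gives a number 23.1 percentage points lower from compound 2 to compound 4 (beyond the scatter), so compound 4 is the lowest of the four, while compounds 1, 2 and 3 remain inseparable from one another. Among the compounds shown here, nothing available here explains why this one move of the bromine lowers the number so far.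

The compounds shown leave open whether the lower number belongs to bromo specifically, as a chloro, a methyl or an amine in place of the bromine in compound 4 could show. They also leave open how the compounds differ in potency, as every number here is a single-concentration read-out.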